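Phenyl sulfonate stilbenoids: hydroxy in place of methoxy

The source may hold more compounds than are shown below. What is called first, only, known or untested is meant among the compounds shown, and "the series" means these compounds.

Measured compounds:
- Compound 1 `COc1cc(/C=C/c2ccc(C3=C(c4ccc(O)cc4)C4CC(S(=O)(=O)Oc5ccccc5)C3O4)cc2)cc(OC)c1`. In a functional assay on MCF7 cells (Homo sapiens) for antiproliferative activity, read by MTT assay, with a stated time of 72 h (a higher number here means a weaker inhibitor, a lower number a stronger inhibitor), compound 1 gives > 100000 nM; this is a limit of the assay, not a number.
- Compound 2 `O=S(=O)(Oc1ccccc1)C1CC2OC1C(c1ccc(/C=C/c3cc(O)cc(O)c3)cc1)=C2c1ccc(O)cc1`. In this assay compound 2 gives 20100 nM.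
- Compound 3 `COc1cc(/C=C/c2ccc(OS(=O)(=O)C3CC4OC3C(c3ccc(O)cc3)=C4c3ccc(O)cc3)cc2)cc(OC)c1`. In this assay compound 3 gives 3700 nM.

Among the measured compounds shown here, the one change measured is 3,5-dihydroxyphenyl in place of 3,5-dimethoxyphenyl on a double-bonded chain carbon bound to a double-bonded chain carbon. It made an at least 4.9-fold lower number from compound 1 to compound 2 (0.69 log units; beyond the scatter). The step is known only as a lower bound because of the limit of > 100000 nM in this assay, at which 1 of the 3 values shown sits.

Compound 3 carries the sulfonate on a different part of the molecule than compound 1 does; the difference between the two cores is not broken down here. Among the two numbers in this assay compound 3 holds the lowest, and the gap to compound 2 lies beyond the scatter.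

Compound 4 `O=S(=O)(Oc1ccc(/C=C/c2cc(O)cc(O)c2)cc1)C1CC2OC1C(c1ccc(O)cc1)=C2c1ccc(O)cc1` is not yet measured. Its difference from compound 3 is 3,5-dihydroxyphenyl in place of 3,5-dimethoxyphenyl on a double-bonded chain carbon bound to a double-bonded chain carbon, the same change as from compound 1 to compound 2, on the same kind of place.

The expectation for this assay rests on compound 1 and compound 2, where the same change made an at least 4.9-fold lower number from compound 1 to compound 2 (0.69 log units; beyond the scatter). On that basis the step is expected to be a 4.9-fold lower number from compound 3 to compound 4 (0.69 log units; beyond the scatter). Compound 4 is therefore estimated at 750 nM, expected to lie between 250 nM and 3000 nM. For the measured compounds named here, since only one example of the change is measured, and that one only as a bound, the range is kept wide.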

Compound 4, half-maximal inhibitory concentration: 10500 nM
Beside the measured number, compound 4's estimate is 14-fold (1.15 log units) below it; measured number outside the range, above it.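

In this assay the same exchange of 3,5-dimethoxyphenyl for 3,5-dihydroxyphenyl gave a 2.8-fold higher number from compound 3 to compound 4 (0.45 log units; beyond the scatter), so on the core of compound 3 the number moved the opposite way to the earlier step. Set side by side, the outcome of this change did not carry from one core to the other: the same change on two cores in this assay, an at least 4.9-fold lower number (0.69 log units; beyond the scatter) from compound 1 to compound 2 and a 2.8-fold higher number (0.45 log units; beyond the scatter) from compound 3 to compound 4, at least 14-fold (1.14 log units) apart, beyond the scatter of two such steps. This rests on a single pair per core, so it shows a dependence on the core within these four compounds only, gives no rule for any further core and offers no explanation for the reversal, and the step starting from compound 1 is only a bound, as compound 1 stands at a limit of the assay: the limit of > 100000 nM in this assay, at which 1 of the 4 values shown sits.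

Open, from the compounds shown here alone, is whether a ring carrying one methoxy and one hydroxy would fall on the side of the dimethoxy or of the dihydroxy compound on each core, and whether an amine or a carboxylic acid in place of the hydroxy groups would follow either direction. Also open, going by these compounds, is whether the difference between the two cores persists when the phenyl on the sulfonate of compound 1 and compound 2 is replaced by a longer chain.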